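Compound 3: a new aryl group on the shared core

A few compounds are considered here, and "the series" means these few. Any claim that something is new, unique, unknown or untested is made for them only; others in the source may bear on it.

Compound 1 `Cc1ccccc1-c1nnc(SCCn2c([N+](=O)[O-])cnc2C)o1`: 15800 nM
Compound 2 `Cc1ncc([N+](=O)[O-])n1CCSc1nnc(-c2ccc(Cl)cc2)o1`: 18700 nM

Only these two compounds have been measured in a functional assay on MCF7 cells (Homo sapiens) for cytotoxicity, read by MTT assay, with a stated time of 48 h; a lower number here means a stronger inhibitor, a higher number a weaker inhibitor. Compound 2 gives 18700 nM and stands level with compound 1 at 15800 nM, since the two values lie within the scatter of each other.

The unmeasured compound 3 `Cc1ccc(-c2nnc(SCCn3c([N+](=O)[O-])cnc3C)o2)c(O)c1` has 2-hydroxy-4-methylphenyl in place of the 4-chlorophenyl of compound 2 on an aromatic carbon (2-hydroxy-4-methylphenyl in place of 4-chlorophenyl on an aromatic carbon).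

Within the data shown here, one measured step bears on this change, and it also exchanges the group at this place: a 1.2-fold higher number from compound 1 to compound 2 (0.07 log units; within the scatter). That step is small, but it is the only one available. Neither measured compound carries the 2-hydroxy-4-methylphenyl group, so the data offer no direct test of it and favour no direction. A change beyond the scatter is therefore not expected, and the estimate is a 1.2-fold lower number from compound 2 to compound 3 (0.07 log units; within the scatter). For compound 3 the estimated value in this assay is 16000 nM, with an expected range from 6500 nM to 40000 nM.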

Compound 3, half-maximal inhibitory concentration: 23500 nM
The estimate for compound 3 lay 1.5-fold (0.17 log units) below the measured number; the range from low to high includes it.
By their numbers in this assay, from the lowest: compounds 1, 2 and 3 (each within the scatter of the next).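

Placing 2-hydroxy-4-methylphenyl on this aromatic carbon of the shared core gives, in this assay, a 1.3-fold higher number from compound 2 to compound 3 (0.10 log units; within the scatter), and the comparison with the 2-methylphenyl group gives a 1.5-fold higher number from compound 1 to compound 3 (0.17 log units; within the scatter). The entering group carries a hydrogen-bond donor and a hydrogen-bond acceptor that 4-chlorophenyl lacks, yet neither step leaves the scatter, so the three substituted phenyl groups seen here at this position stand level with one another. No evidence is available to explain why these numbers stay level.

From the compounds shown here alone, all three compounds carry a substituted phenyl group at this place, so it remains open whether an amine, a carboxylic acid or a longer alkyl chain on this carbon would move the number beyond the scatter. The compounds also leave open what the hydroxy and methyl substituents of the new group contribute separately, and what part the nitro group, shared by all three compounds, plays in their cytotoxicity.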